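A few compounds are considered here, and "the series" means these few. Any claim that something is new, unique, unknown or untested is made for them only; others in the source may bear on it.

Among the measured compounds shown here, compound 2 `COc1cccc(COc2ccccc2OCCNCCOc2c(OC)cccc2OC)c1` is one of two compounds measured in a functional assay on PC-3 cells (Homo sapiens) for cytotoxicity, read by sulforhodamine B assay; on this read-out higher numbers stand for weaker inhibition of growth and lower numbers for stronger inhibition of growth; there compound 2 gives 15100 nM. For the measured compounds named here, the only other measured compound, compound 1 `COc1cccc(OC)c1OCCNCCOc1ccccc1OCc1ccccc1Cl`, gives 17800 nM, and the step of a 1.2-fold lower number from compound 1 to compound 2 (0.07 log units; within the scatter) lies within the scatter, so compound 2 has the lower of the two numbers without standing apart from compound 1.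

Compound 3 `COc1cccc(OC)c1OCCNCCOc1ccccc1OCc1ccc(OC(C)C)cc1` differs from compound 2 by 4-isopropoxyphenyl in place of 3-methoxyphenyl on a saturated chain carbon bound to an oxygen on an aromatic ring. Going by the values given here, the one measured step that bears on this place is the exchange of one aryl group for another on the same saturated chain carbon, from compound 1 to compound 2, and that step, a 1.2-fold lower number from compound 1 to compound 2 (0.07 log units; within the scatter), stayed within the scatter. On that basis no step beyond the scatter is expected in this assay, in either direction, and the expected step of a 1.0-fold lower number from compound 2 to compound 3 (0.00 log units; within the scatter) is small. Compound 3 is therefore estimated at 15000 nM, with a range from 6000 nM to 40000 nM.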

Compound 3, concentration for total growth inhibition: 17800 nM
Compound 3: the middle estimate sits 1.2-fold (0.07 log units) below what was measured; the measured number falls inside the stated range.
By their numbers in this assay, from the lowest: compounds 2, 1 and 3 (each within the scatter of the next).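

In this assay the step of a 1.2-fold higher number from compound 2 to compound 3 (0.07 log units; within the scatter) shows that this saturated chain carbon also tolerates 4-isopropoxyphenyl, a group with more heavy atoms than 3-methoxyphenyl, without a step beyond the scatter. Against the 2-chlorophenyl group, the same exchange gives no change at the digits printed from compound 1 to compound 3 (within the scatter), so the three aryl groups shown at this place, which differ in substituent and in where it stands, all lie within the scatter of one another. No measurement at hand offers an explanation for this.

Going by these compounds, whether an amine or a carboxylic acid on this aryl ring, or a longer chain in place of the benzyl link, would carry the number beyond the scatter remains open. So does whether any change elsewhere in the shared core would do so.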